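Meta chloro for trifluoromethyl on the aryl ring

The compounds below may be only part of what the source reports. "The series", "measured", "known", "first", "only" and "open" are said of these compounds alone.

Working notes on the series, which is read out in a functional assay on the whole organism for inhibition, with Rattus norvegicus as the target, at a dose of 30 mg/kg; a lower number here means less inhibition, a higher number more inhibition at the dose given (going by the name of the read-out). Compound 1 `Clc1ccccc1-c1nc2ncccc2o1` gives 38%, compound 2 `COc1ccccc1-c1nc2ncccc2o1` gives 9%, and compound 3 `FC(F)(F)c1cccc(-c2nc3cccnc3o2)c1` gives 7%. Compound 3 stands lowest of the three numbers, within the scatter of compound 2 and beyond the scatter below compound 1. Within the data shown here, the one single-place step measured so far, a number 29 percentage points lower from compound 1 to compound 2 (beyond the scatter), shows that replacing chloro changes this assay substantially.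

Compound 4 `Clc1cccc(-c2nc3cccnc3o2)c1` is compound 3 with chloro in place of trifluoromethyl on an aromatic carbon. Among the measured compounds shown here, no measured step covers exactly this change; compound 1 also carries a chloro, but it is not a single-change neighbour of compound 4, so only the two values of compound 1 and compound 3 can be set side by side. Given that the chloro-bearing compound 1 gives 38% while compound 3 gives 7%, a rise is expected, estimated as a number 13 percentage points higher from compound 3 to compound 4 (beyond the scatter). Compound 4 is therefore expected to give about 20% in this assay, with a range from 5% to 40%.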

Compound 4, a percentage reported as inhibition, in the whole organism at one dose (the size of the read-out at that dose, not a potency): 8%
Compound 4: middle estimate off by 12 percentage points, on the high side; measured number inside the range.
By their numbers in this assay, from the lowest: compounds 3, 4 and 2 (each within the scatter of the next); then compound 1.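

In this assay, the step of a number 1 percentage points higher from compound 3 to compound 4 (within the scatter) gives no reading that separates chloro from trifluoromethyl on this aromatic carbon, meta to a group of 9 heavy atoms. At this position, then, a group of 1 heavy atom and one of 4 heavy atoms cannot be told apart by this read-out, whereas the earlier step of a number 29 percentage points lower from compound 1 to compound 2 (beyond the scatter) concerned methoxy for chloro at another place on another core. No measurement on hand accounts for this result.

Going by these compounds, what remains open is whether any group at this position moves the number beyond the scatter, for instance an amine, a carboxylic acid or a longer alkyl chain. Also open, on these data alone, is whether chloro and trifluoromethyl would still read alike on the core of compound 1.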